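The source may hold more compounds than are shown below. What is called first, only, known or untested is meant among the compounds shown, and "the series" means these compounds.

Measured so far:
Compound 1 `NC(=O)c1c(NC(=O)c2ccc(Cl)cc2)sc2c1CCN(Cc1ccccc1)C2` — in an ADME assay on RAW264.7 cells (Mus musculus) for cytotoxicity, read by MTT assay, with a stated time of 48 h, tested at 50 uM (a lower number here means less inhibition, a higher number more inhibition at the concentration tested (going by the name of the read-out)), compound 1 gives 11.1%
Compound 2 `CC(C)(C)OC(=O)N1CCc2c(sc(NC(=O)c3ccc(OCc4ccccc4)cc3)c2C(N)=O)C1` — in this assay compound 2 gives 52.1%

Compound 2 holds the higher of the two numbers in this assay; compound 1 lies well below it, and the gap between them is beyond the scatter. The two compounds differ in more than one place, so no single structural change can be tied to that gap; only the two values themselves are known.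

Compound 3 `NC(=O)c1c(NC(=O)c2ccc(OCc3ccccc3)cc2)sc2c1CCN(Cc1ccccc1)C2` has not been measured. It keeps the amide side of compound 2 and alters only the ring nitrogen: benzyl in place of tert-butoxycarbonyl on an amine nitrogen in a ring. The same benzyl sits on that nitrogen in compound 1. For the measured compounds named here, no step between measured compounds isolates this change, so its size is not fixed by the data. Going by the values given here, a fall from compound 2 is expected rather than a rise, because the only benzyl-bearing compound 1 gives 11.1% in this assay, although its amide part is also different. The expected step is a number 27.1 percentage points lower from compound 2 to compound 3 (beyond the scatter). Compound 3 is estimated at 25%, within 5% to 50%.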

Compound 3, a percentage reported as inhibition, at one concentration (the size of the read-out at that concentration, not a potency): 24%
Compound 3: the middle estimate sits 1 percentage points above what was measured; the range from low to high includes it.
By their numbers in this assay, from the lowest: compound 1; then compound 3; then compound 2.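

In this assay, the ring nitrogen now has a step of its own: with the benzyloxy amide side held constant, benzyl in place of tert-butoxycarbonyl on an amine nitrogen in a ring gives a number 28.1 percentage points lower from compound 2 to compound 3 (beyond the scatter), so a change at this position alone moves the read-out. With benzyl held on that nitrogen, benzyloxy in place of chloro on an aromatic carbon gives a number 12.9 percentage points higher from compound 1 to compound 3 (beyond the scatter), so the aromatic substituent also moves the read-out without any change at the ring nitrogen. For the compounds shown here, the single gap between compound 1 and compound 2 could not separate these two places, whereas compound 3 links both of them by one-place steps, each beyond the scatter.

The compounds shown leave open how the read-out runs with a free amine or an acetyl group on the ring nitrogen, or with a methoxy group or a carboxylic acid in place of benzyloxy, and whether each step keeps its size when the other place carries a different group. No measurement shown here bears on what lies behind either step.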